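This account rests on a few compounds, and the source may have more. Where it says the series, first, only, none or still open, it means among the compounds named here.

Compound 1 `CC(=O)O[C@H]1CC[C@]2(C)[C@H](CC[C@@](C)(O)[C@H]2CC[C@@H]2C(C)=CC[C@H]3[C@H](CC[C@]3(C)O)C2(C)C)OC1(C)C`: 47900 nM
Compound 2 `CC1=CC[C@H]2[C@H](CC[C@]2(C)O)C(C)(C)[C@@H]1CC[C@H]1[C@]2(C)CC[C@H](OC(=O)c3ccc(C(F)(F)F)cc3)C(C)(C)O[C@H]2CC[C@@]1(C)O`: 23400 nM

In a functional assay on MCF7 cells (Homo sapiens) for antiproliferative activity, read by MTT assay, with a stated time of 72 h (a lower number here means a stronger inhibitor, a higher number a weaker inhibitor), compound 2 gives the lower of the two numbers, 23400 nM. Compound 3 `CC1=CC[C@H]2[C@H](CC[C@]2(C)O)C(C)(C)[C@@H]1CC[C@H]1[C@]2(C)CC[C@H](OC(=O)c3cccc(C(F)(F)F)c3)C(C)(C)O[C@H]2CC[C@@]1(C)O` differs from compound 2 as follows: 3-(trifluoromethyl)phenyl in place of 4-(trifluoromethyl)phenyl on a carbonyl carbon. The same group stays on the carbonyl carbon, and only its substitution changes. Among the compounds with values here, the one measured step that bears on this is a 2.0-fold lower number from compound 1 to compound 2 (0.31 log units; beyond the scatter), a modest step that replaced methyl and so says little about this change. No step beyond the usual scatter is expected. The expected step is a 1.1-fold higher number from compound 2 to compound 3 (0.03 log units; within the scatter). For compound 3 the estimate is 25000 nM, with an expected range of 11000 nM to 55000 nM.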

Compound 3, half-maximal inhibitory concentration: 37900 nM
For compound 3 the middle estimate is 1.5-fold (0.18 log units) below the measured one; the measured number falls inside the stated range.
By their numbers in this assay, from the lowest: compounds 2, 3 and 1 (each within the scatter of the next, the first and the last beyond it).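

In this assay, 3-(trifluoromethyl)phenyl in place of 4-(trifluoromethyl)phenyl on the carbonyl carbon gives a 1.6-fold higher number from compound 2 to compound 3 (0.21 log units; within the scatter), so these two substitution patterns are not separated here. With 3-(trifluoromethyl)phenyl in place of methyl, the result is a 1.3-fold lower number from compound 1 to compound 3 (0.10 log units; within the scatter), so only 4-(trifluoromethyl)phenyl stands apart from methyl, and only by a small margin. No measurement shown explains these numbers.

Unsubstituted phenyl, 4-methoxyphenyl and pyridyl remain open on this carbonyl carbon. So does whether a group carrying an amine or a carboxylic acid would give a larger step.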